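Benzofuran in Place of Indazole on the Side Arm

The compounds below may be only part of what the source reports. "The series", "measured", "known", "first", "only" and "open" are said of these compounds alone.

In a physicochemical assay for lipophilicity, at pH 7.4 (a higher number here means a more lipophilic compound, a lower number a more polar compound), compound 1 `CNC(=O)c1cc(C(=O)NC2CC2)cn(CC2CCOCC2)c1=O` gives 1.5, compound 2 `CNC(=O)c1cc(C(=O)NC2CC2)cn(Cc2nccc3[nH]ccc23)c1=O` gives 1.7, and compound 3 `CNC(=O)c1cc(C(=O)NC2CC2)cn(Cc2cccc3[nH]ncc23)c1=O` gives 1.5. Compound 3 thus stands level with compound 1, the two together being the lowest of the three numbers, while a number 0.20 log units lower from compound 2 to compound 3 (within the scatter). Compound 4 `CNC(=O)c1cc(C(=O)NC2CC2)cn(Cc2cccc3occc23)c1=O` differs from compound 3 by 1-benzofuran-4-yl in place of 1H-indazol-4-yl on a saturated chain carbon bound to an aromatic nitrogen. The steps at this same position, no change at the digits printed from compound 1 to compound 3 (within the scatter) and a number 0.20 log units lower from compound 2 to compound 3 (within the scatter), both lay within the scatter, but neither of them swapped a group carrying one hydrogen-bond donor for one carrying none, as this change does. A rise beyond the scatter in this assay is therefore expected, a number 1.00 log units higher from compound 3 to compound 4 (beyond the scatter). Compound 4 is estimated at 2.5, with a range from 2 to 3.1.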

Compound 4, distribution coefficient: 3.4
For compound 4 the middle estimate is 0.90 log units below the measured one, outside the stated range (above it).
By their numbers in this assay, from the lowest: compounds 1, 3 and 2 (each within the scatter of the next); then compound 4.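

In this assay, within the data shown here, the side arm proves able to move the number far: 1-benzofuran-4-yl in place of 1H-indazol-4-yl gives a number 1.90 log units higher from compound 3 to compound 4 (beyond the scatter), whereas the earlier steps here stayed within the scatter. The same group also stands clear of both other side arms, with a number 1.70 log units higher from compound 2 to compound 4 (beyond the scatter) and a number 1.90 log units higher from compound 1 to compound 4 (beyond the scatter). Nothing given here accounts for the size of these steps. Going by these compounds, whether 1-benzothiophen-4-yl or a plain phenyl on the same carbon would reach a similar number remains open.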